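The source may hold more compounds than are shown below. What is called first, only, known or untested is meant among the compounds shown, and "the series" means these compounds.

Of the compounds shown here, three on a shared core have been measured so far in a functional assay on SK-OV-3 cells (Homo sapiens) for antiproliferative activity, read by MTT assay, with a stated time of 72 h (on this read-out higher numbers stand for weaker inhibition and lower numbers for stronger inhibition), with a bromo, an isopropyl or an ethynyl group on the aromatic ring of the anilide side. Here compound 1 (`O=C(CCc1cccc2c1B(O)OC2)Nc1cccc(Br)c1`) gives 540 nM as its reading, compound 2 (`CC(C)c1cccc(NC(=O)CCc2cccc3c2B(O)OC3)c1`) gives 510 nM as its reading, and compound 3 (`C#Cc1cccc(NC(=O)CCc2cccc3c2B(O)OC3)c1`) gives 980 nM as its reading. Compound 3 thus lies within the scatter of both others. The measured steps to it are a 1.8-fold higher number from compound 1 to compound 3 (0.26 log units; within the scatter) and a 1.9-fold higher number from compound 2 to compound 3 (0.28 log units; within the scatter) while a 1.1-fold lower number from compound 1 to compound 2 (0.02 log units; within the scatter) also stays inside the scatter.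

Compound 4 (`O=C(CCc1cccc2c1B(O)OC2)Nc1cccc(-c2cccc(F)c2)c1`) carries 3-fluorophenyl in place of ethynyl on an aromatic carbon, meta to a large group. For the measured compounds named here, the exchanges among bromo, isopropyl and ethynyl on that carbon are the steps that bear on this change, although none of those groups holds a ring, so the data offer no direct guide to the entering one. Even a 1.9-fold higher number from compound 2 to compound 3 (0.28 log units; within the scatter) stays small, so no step beyond the scatter is expected in this assay here. The estimated change is a 1.6-fold lower number from compound 3 to compound 4 (0.21 log units; within the scatter) and it is not expected to leave the scatter. For compound 4 the expected value is 600 nM with an estimated range from 200 nM to 1800 nM as a wide allowance for the new ring.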

Compound 4, half-maximal inhibitory concentration: 480 nM
Compound 4: middle estimate off by 1.3-fold (0.10 log units), on the high side; the measured number falls inside the stated range.
By their numbers in this assay, from the lowest: compounds 4, 2, 1 and 3 (each within the scatter of the next, the first and the last beyond it).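

In this assay, for the compounds shown here, the 3-fluorophenyl group is the first group on this aromatic carbon to hold a ring, and the reading stays in the range of the smaller groups: its exchange for ethynyl gives a 2.0-fold lower number from compound 3 to compound 4 (0.31 log units; beyond the scatter), the only step at this position so far to pass beyond the scatter, and a modest one. Its exchanges for the two other groups stay inside the scatter, with a 1.1-fold lower number from compound 2 to compound 4 (0.03 log units; within the scatter) and a 1.1-fold lower number from compound 1 to compound 4 (0.05 log units; within the scatter), so this carbon accepts the aromatic ring with no separation from isopropyl or bromo, and only the ethynyl compound stands apart from compound 4. No measurement on these compounds speaks to what lies behind the step from ethynyl.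

On these data alone, it remains open whether the fluorine on the entering ring matters at all, a question that a plain phenyl or a 4-fluorophenyl group on this carbon would address. As far as these compounds go, it is equally open how this carbon would respond to a group carrying an amine or a carboxylic acid, or to a longer chain, as none of the four compounds holds such a group there.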